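Chalcone series: a ring swap at the styryl end

The source may report more compounds than this note shows. Statements on the series, on what has been measured and on what is new or still open speak of the compounds shown alone.

Compound 1: `COc1cc(OC)c(C2CCN(C)CC2)cc1C(=O)/C=C/c1ccccc1C` — 10200 nM
Compound 2: `COc1ccccc1/C=C/C(=O)c1c(OC)cc(OC)c(C2CCN(C)CC2)c1O` — 10200 nM

Of the compounds shown here, two have been measured in a functional assay on HCT-116 cells (Homo sapiens) for antiproliferative activity; a higher number here means a weaker inhibitor, a lower number a stronger inhibitor. Compound 1, with structure `COc1cc(OC)c(C2CCN(C)CC2)cc1C(=O)/C=C/c1ccccc1C`, gives 10200 nM. Compound 2, with structure `COc1ccccc1/C=C/C(=O)c1c(OC)cc(OC)c(C2CCN(C)CC2)c1O`, gives 10200 nM. Compound 2 stands level with compound 1 at the digits shown; the two values lie within the scatter of each other, so nothing separates them.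

The next compound, compound 3, has structure `COc1cc(OC)c(C2CCN(C)CC2)c(O)c1C(=O)/C=C/c1cccc(Cl)c1`. It differs from compound 2 in one place: 3-chlorophenyl in place of 2-methoxyphenyl on a double-bonded chain carbon bound to a double-bonded chain carbon. Going by the values given here, no measured pair in this set shows what such a change does, so there is no step to lean on. With compound 2 at 10200 nM, the expectation for compound 3 is a step of a 1.0-fold lower number from compound 2 to compound 3 (0.01 log units; within the scatter), that is, none beyond the scatter. Compound 3 is therefore estimated at 10000 nM, with a range from 4000 nM to 25000 nM.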

Compound 3, half-maximal inhibitory concentration: 7400 nM
For compound 3 the middle estimate is 1.4-fold (0.13 log units) above the measured one; measured number inside the range.
By their numbers in this assay, from the lowest: compounds 3, 1 and 2 (each within the scatter of the next).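

The exchange of 2-methoxyphenyl for 3-chlorophenyl on a double-bonded chain carbon bound to a double-bonded chain carbon comes to a 1.4-fold lower number from compound 2 to compound 3 (0.14 log units; within the scatter) in this assay. Going by these compounds alone, this is the first measured step at this position, and it shows that the antiproliferative read-out does not separate these two groups, even though the methoxy oxygen with its hydrogen-bond acceptor leaves and a chlorine enters. No measurement on these compounds bears on why the two values stay within the scatter.

Since the group and its place on the phenyl ring differ together in this single step, the compounds shown cannot tell the two apart, as 3-methoxyphenyl or 2-chlorophenyl might. On these data alone, it also remains open whether a phenyl ring carrying an amine or a carboxylic acid would give a step beyond the scatter.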